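An Aromatic Amine in Place of a Cyclopentyl Amine

This account rests on a few compounds, and the source may have more. Where it says the series, first, only, none or still open, it means among the compounds named here.

The measured compounds:
Compound 1 `O=C1C(NC2CCCC2)=CC(=O)c2c1nc1n2[C@H]2OC[C@@H](O)[C@H]2OC1`: in a functional assay on MGC-803 cells (Homo sapiens) for inhibition, read by sulforhodamine B assay (on this read-out higher numbers stand for weaker inhibition and lower numbers for stronger inhibition), compound 1 gives > 16000 nM, which is a limit of the assay rather than a number.
Compound 2 `COc1ccccc1NC1=CC(=O)c2nc3n(c2C1=O)[C@H]1OC[C@@H](O)[C@H]1OC3`: in this assay compound 2 gives 1630 nM.
Compound 3 `CCCN(CCC)C1=CC(=O)c2nc3n(c2C1=O)[C@H]1OC[C@@H](O)[C@H]1OC3`: in this assay compound 3 gives > 16000 nM, again a limit of the assay, not a number.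

All three share one core and differ only in the amine on the double-bonded ring carbon. Compound 1 stands at the limit, so no number places it against compound 2; it is simply not measurable where compound 2 is. Going by the values given here, the one step between measured neighbours, an at least 9.8-fold higher number from compound 2 to compound 3 (0.99 log units; beyond the scatter), shows an aromatic amine measurable where a dialkylamine is not, a pattern tied to the limit of > 16000 nM in this assay, at which 2 of the 3 values shown sit.

Compound 4 `CCOc1ccccc1NC1=CC(=O)c2c(nc3n2[C@H]2OC[C@@H](O)[C@H]2OC3)C1=O` is compound 1 with 2-ethoxyphenyl in place of cyclopentyl on an amine nitrogen. The entering 2-ethoxyphenyl resembles the (2-methoxyphenyl)amino of compound 2 far more than the cyclopentyl it replaces. A move toward stronger inhibition in this assay is therefore expected, an at least 8.0-fold lower number from compound 1 to compound 4 (0.90 log units; beyond the scatter), with compound 2 and its 1630 nM as the guide. Compound 4 is estimated at 2000 nM, with a range from 700 nM to 6000 nM.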

Compound 4, half-maximal inhibitory concentration: 2830 nM
Beside the measured number, compound 4's estimate is 1.4-fold (0.15 log units) below it, within the range that was stated.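

On the amine nitrogen attached to the double-bonded ring carbon, replacing cyclopentyl with 2-ethoxyphenyl gives an at least 5.6-fold lower number from compound 1 to compound 4 (0.75 log units; beyond the scatter) in this assay. Unlike the earlier step to the dipropylamino group of compound 3, this change leaves the hydrogen on the amine nitrogen in place on both sides, so a compound at the limit need not lack that hydrogen, and the aromatic ring marks the difference even when the hydrogen stays. The step can only be given as a minimum, and its true size stays unknown, because compound 1 is held only at a limit of the assay and not at a number: the limit of > 16000 nM in this assay, at which 2 of the 4 values shown sit.

The compounds shown leave open whether the aromatic ring alone is enough or the alkoxy group on it is also needed, and a plain phenyl on the same nitrogen would separate those two readings. They also leave open whether a benzyl group, which sets a carbon between the nitrogen and the aromatic ring, would stay measurable in this assay or fall to the limit.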